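Hydrazone aryl swap on a shared quinazoline-free core

The source may report more compounds than this note shows. Statements on the series, on what has been measured and on what is new or still open speak of the compounds shown alone.

The series shares one core, varied only at the aryl group on the hydrazone carbon. Compound 1 `O=C(N/N=C/c1ccc(F)cc1)Nc1cc2c(Nc3ccc(F)c(Cl)c3)ncnc2cc1O[C@H]1CCOC1` is reported in a functional assay on PC-3 cells (Homo sapiens) for cytotoxicity, read by MTT assay, with a stated time of 72 h (on this read-out lower numbers stand for stronger inhibition and higher numbers for weaker inhibition), as "not active" (no number reported), with no single number given, so it stands without a numerical anchor. Going by the values given here, compound 2 `COc1ccc(/C=N/NC(=O)Nc2cc3c(Nc4ccc(F)c(Cl)c4)ncnc3cc2O[C@H]2CCOC2)cc1` gives 34100 nM in this assay, and compound 3 `COc1ccc(/C=N/NC(=O)Nc2cc3c(Nc4ccc(F)c(Cl)c4)ncnc3cc2O[C@H]2CCOC2)c(OC)c1OC` gives 25600 nM; the only measured step, a 1.3-fold lower number from compound 2 to compound 3 (0.12 log units; within the scatter), lies within the scatter and points to no meaningful shift from adding methoxy groups to the aryl ring.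

Compound 4 `O=C(N/N=C/c1ccc(O)cc1O)Nc1cc2c(Nc3ccc(F)c(Cl)c3)ncnc2cc1O[C@H]1CCOC1` differs from compound 1 by 2,4-dihydroxyphenyl in place of 4-fluorophenyl on a carbon with a double bond to nitrogen. Among the compounds with values here, no measured step bears directly on this exchange, since the only measured pair concerns methoxyphenyl variants rather than a change from fluorophenyl to dihydroxyphenyl. What the data do show is that every aryl variant measured here sits in the weak range, and that compound 1 itself lacks a number. Within the data shown here, with no directional precedent, no step beyond the scatter is expected in this assay, and the outcome is uncertain in both directions.

Compound 4 is therefore expected to give about 30000 nM in this assay, with a plausible range from 10000 nM to 100000 nM, and a real chance that only a limit is reported.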

Compound 4, half-maximal inhibitory concentration: 7540 nM
Compound 4: the middle estimate sits 4.0-fold (0.60 log units) above what was measured; measured number outside the range, below it.
By their numbers in this assay, from the lowest: compound 4; then compounds 3 and 2 (each within the scatter of the next).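

In this assay the aryl group on a carbon with a double bond to nitrogen proves able to move the number beyond the scatter: 2,4-dihydroxyphenyl in place of 2,3,4-trimethoxyphenyl gives a 3.4-fold lower number from compound 3 to compound 4 (0.53 log units; beyond the scatter) and in place of 4-methoxyphenyl gives a 4.5-fold lower number from compound 2 to compound 4 (0.66 log units; beyond the scatter), both modest in size. Going by these compounds alone, the earlier pair compared only two methoxy-bearing rings and showed no step beyond the scatter, so compound 4 is the first compound here to separate from the others with a number, and it sits lowest of the three compounds that have one. Nothing measured here accounts for this gain.

As far as these compounds go, it remains open whether a single hydroxy group on this ring would do the same as the two in compound 4, and how a ring carrying an amine or a carboxylic acid would compare in this assay. The exchange of 4-fluorophenyl for 2,4-dihydroxyphenyl also stays unsized, as compound 1 has no number and that step cannot be read.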